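Swapping 4-methylphenyl for hydroxymethyl on the shared core

The source may report more compounds than this note shows. Statements on the series, on what has been measured and on what is new or still open speak of the compounds shown alone.

Compound 1 `Cc1ccc(-c2cn(CCCN3C(=O)COc4ccccc43)nn2)cc1`: > 100000 nM (a limit, not a number)
Compound 2 `CCCCCCc1cn(CCCN2C(=O)COc3ccccc32)nn1`: 150 nM

In a functional assay on MiaPaCa cells (Homo sapiens) for antiproliferative activity, read by sulforhodamine B assay, with a stated time of 48 h (on this read-out higher numbers stand for weaker inhibition of growth and lower numbers for stronger inhibition of growth), compound 1 stands at a limit and not a number: > 100000 nM.

Compound 3 `O=C1COc2ccccc2N1CCCn1cc(CO)nn1` keeps the core of compound 1 and changes one group: hydroxymethyl in place of 4-methylphenyl on an aromatic carbon.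

Among the compounds with values here, only one measured step bears on this place: an at least 660-fold lower number from compound 1 to compound 2 (2.82 log units; beyond the scatter). It is large and beyond the scatter, so a change here can move the number a long way. It shows what hexyl does, however, and not what hydroxymethyl will do. A lower number is therefore expected in this assay, but a far smaller drop than that step, and another limit remains possible.

The expected step is an at least 3.3-fold lower number from compound 1 to compound 3 (0.52 log units; beyond the scatter). For compound 3 the estimate is 30000 nM, with an expected range of 3000 nM to 100000 nM.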

Compound 3, concentration for 50% growth inhibition: 1010 nM
Compound 3: the middle estimate sits 30-fold (1.47 log units) above what was measured; measured number below the stated range.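

In this assay, hydroxymethyl in place of 4-methylphenyl gives an at least 99-fold lower number from compound 1 to compound 3 (1.99 log units; beyond the scatter), so a large drop at this position does not depend on hexyl, and a group as small as hydroxymethyl also brings one. Hexyl still holds the lower number, with a 6.7-fold higher number from compound 2 to compound 3 (0.83 log units; beyond the scatter), but this modest step shows that the two groups lie far closer to each other than either lies to 4-methylphenyl. The step from compound 1 can be read only as a bound, because compound 1 stands at a limit: the limit of > 100000 nM in this assay, at which 1 of the 3 values shown sits.

Whether the loss of the six-membered aromatic ring or the gain of the hydroxy group accounts for the drop stays open, since the change brings both at once. A phenyl ring carrying hydroxymethyl would separate the two, while an amine, a carboxylic acid or a butyl chain at this place remains an untested question among the compounds shown.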